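The source may hold more compounds than are shown below. What is called first, only, known or untested is meant among the compounds shown, and "the series" means these compounds.

Two compounds share a core in which an oxime oxygen carries a quinazolin-4-yl group. Compound 1 `Clc1ccccc1COc1ccccc1/C=C/C(/C=C/c1ccccn1)=N/Oc1ncnc2ccccc12` gives 96% in a functional assay on SMMC-7721 cells (Homo sapiens) for inhibition, read by MTT assay, with a stated time of 72 h, tested at 10 uM; on this read-out lower numbers stand for a weaker effect and higher numbers for a stronger effect at the one concentration tested. Compound 2 `Cc1cccc2ncnc(O/N=C(\C=C\c3ccccn3)/C=C/c3ccccc3OCc3ccccc3Cl)c12` gives 95.7% in this assay. Among the measured compounds shown here, the single step recorded between them, a number 0.3 percentage points lower from compound 1 to compound 2 (within the scatter), lies within the scatter, so the two numbers cannot be ordered; compound 2 stands at the lower of the two numbers, with compound 1 a hair apart and, as said, within the scatter.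

Compound 3 `Clc1ccc2c(O/N=C(\C=C\c3ccccn3)/C=C/c3ccccc3OCc3ccccc3Cl)ncnc2c1` has not been measured. It differs from compound 2 in one place: 7-chloroquinazolin-4-yl in place of 5-methylquinazolin-4-yl on an oxygen. For the measured compounds named here, no measured step involves a chloro group on the quinazolinyl ring, and the one step known, methyl in place of hydrogen on an aromatic carbon, was flat. Nothing in the two numbers therefore points to a step beyond the scatter in this assay in either direction. Compound 3 is accordingly expected to give 93%, with a range from 78% to 99%. The step this estimate means, a number 2.7 percentage points lower from compound 2 to compound 3 (within the scatter), is expected to stay within the scatter.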

Compound 3, a percentage reported as inhibition, at one concentration (the size of the read-out at that concentration, not a potency): 94.5%
Beside the measured number, compound 3's estimate is 1.5 percentage points below it; low and high end bracket the measured number.
By their numbers in this assay, from the lowest: compounds 3, 2 and 1 (each within the scatter of the next).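

In this assay, 7-chloroquinazolin-4-yl in place of 5-methylquinazolin-4-yl on the oxygen gives a number 1.2 percentage points lower from compound 2 to compound 3 (within the scatter), and the comparison with the unsubstituted group gives a number 1.5 percentage points lower from compound 1 to compound 3 (within the scatter). The earlier compounds had shown only that a methyl group on the quinazolinyl ring left the read-out flat; these steps show the same for a chloro group at a second named position, so none of the three compounds can be ordered. Nothing at hand bears on why the chloro group and the methyl group read alike here.

The step from compound 2 to compound 3 changes both the group and its position on the ring, so 5-chloroquinazolin-4-yl and 7-methylquinazolin-4-yl would be needed to tell these two changes apart. From the compounds shown here alone, it also remains open whether an amine, a carboxylic acid or a longer alkoxy chain on that ring would stay within the scatter, and whether the three compounds would separate at a lower concentration, since this read-out is not a potency.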